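Demethylation of one methoxy group in the naphthyl pyrazoline series

A few compounds are considered here, and "the series" means these few. Any claim that something is new, unique, unknown or untested is made for them only; others in the source may bear on it.

The series shares an acetylated pyrazoline core carrying a naphthyl group, and differs in the aryl group on the saturated ring carbon. Compound 1 `CC(=O)N1N=C(c2cccc3ccccc23)CC1c1ccccc1[N+](=O)[O-]` gives 3540 nM in a functional assay on PC-3 cells (Homo sapiens) for cytotoxicity, read by sulforhodamine B assay, with a stated time of 48 h; on this read-out lower numbers stand for stronger inhibition and higher numbers for weaker inhibition. Compound 2 `CC(=O)N1N=C(c2cccc3ccccc23)CC1c1cccc(Cl)c1Cl` gives 20100 nM in this assay. Compound 3 `COc1ccc(C2CC(c3cccc4ccccc34)=NN2C(C)=O)cc1OC` gives 2010 nM in this assay. Within the data shown here, the one measured step, a 5.7-fold higher number from compound 1 to compound 2 (0.75 log units; beyond the scatter), concerns the aryl group as a whole. Compound 3 and compound 1 lie within the scatter of each other, while compound 2 stands beyond both.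

Compound 4 `COc1cc(C2CC(c3cccc4ccccc34)=NN2C(C)=O)ccc1O` is the next member, not yet measured. Relative to compound 3 the change is hydrogen in place of methyl on an oxygen on an aromatic ring, the methoxy-to-hydroxy cut. Among the measured compounds shown here, no measured step touches a change on an oxygen of the aryl ring; the only measured step swaps the whole aryl group, so it gives no direct guide. In the absence of any bearing step, the expectation for compound 4 is no step beyond the scatter in this assay, which is a 1.5-fold higher number from compound 3 to compound 4 (0.17 log units; within the scatter) in estimate. Compound 4 is therefore expected to give about 3000 nM in this assay, with a range from 1200 nM to 8000 nM.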

Compound 4, half-maximal inhibitory concentration: 2130 nM
Beside the measured number, compound 4's estimate is 1.4-fold (0.15 log units) above it, within the range that was stated.
By their numbers in this assay, from the lowest: compounds 3, 4 and 1 (each within the scatter of the next); then compound 2.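

In this assay, among these compounds, the methoxy-to-hydroxy cut on an oxygen on an aromatic ring gives a 1.1-fold higher number from compound 3 to compound 4 (0.03 log units; within the scatter) and so stays within the scatter, the first reading of a change made on this oxygen rather than of a swap of the whole aryl group. Compared across aryl groups, 4-hydroxy-3-methoxyphenyl in place of 2,3-dichlorophenyl gives a 9.4-fold lower number from compound 2 to compound 4 (0.97 log units; beyond the scatter) and stands beyond the scatter, whereas in place of 2-nitrophenyl it gives a 1.7-fold lower number from compound 1 to compound 4 (0.22 log units; within the scatter) and stays within it, so compound 4 joins compound 1 and compound 3 in the group apart from compound 2. No supporting information is available to explain these steps.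

The compounds shown leave open whether an ethoxy group or a longer chain on the same oxygen, or an amine in place of the hydroxy, would also stay within the scatter of compound 3. Among the compounds shown here, they also leave open whether the same cut would remain this small on other aryl groups, as compound 3 and compound 4 form the only pair that carries it.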